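A few compounds are considered here, and "the series" means these few. Any claim that something is new, unique, unknown or untested is made for them only; others in the source may bear on it.

Of the compounds shown here, three of a shared core have been tested in a functional assay on HepG2 cells (Homo sapiens) for cytotoxicity, read by MTT assay, with a stated time of 24 h; a lower number here means a stronger inhibitor, a higher number a weaker inhibitor. Compound 1 `COc1cc(/C=C2\CN(S(=O)(=O)c3ccc(F)cc3)C/C(=C\c3ccccc3F)C2=O)cc(OC)c1OC` gives 7940 nM. Compound 2 `COc1cc(/C=C2\CN(S(=O)(=O)c3ccc(F)cc3)C/C(=C\c3ccccc3F)C2=O)cc(OC)c1` gives 9300 nM in this assay, and a 1.2-fold higher number from compound 1 to compound 2 (0.07 log units; within the scatter), the change being (hydrogen in place of methoxy on an aromatic carbon). Compound 3 `COc1cc(/C=C2\CN(S(=O)(=O)c3ccc(NC(C)=O)cc3)C/C(=C\c3ccccc3F)C2=O)cc(OC)c1OC` gives 4750 nM in this assay. Compound 3 differs from compound 1 in its core, by acetamido in place of fluoro on an aromatic carbon, and a 1.7-fold lower number from compound 1 to compound 3 (0.22 log units; within the scatter). Compound 3 thus carries the lowest of the three numbers, yet its gaps to compound 1 and to compound 2 both lie within the scatter, so no order among the three can be claimed.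

Compound 4 `COc1cc(/C=C2\CN(S(=O)(=O)c3ccc(NC(C)=O)cc3)C/C(=C\c3ccccc3F)C2=O)cc(OC)c1` has not yet been measured in this assay. It differs from compound 3 by hydrogen in place of methoxy on an aromatic carbon, which is the same change that takes compound 1 to compound 2, in the same surroundings: on an aromatic carbon of a six-membered aromatic ring of carbon only, ortho to two methoxy groups and para to a large group. Within the data shown here, the one measured instance of this change, a 1.2-fold higher number from compound 1 to compound 2 (0.07 log units; within the scatter), stayed within the scatter. Among the measured compounds shown here, with only this single precedent, and with the core of compound 3 differing from the core of compound 1 by acetamido in place of fluoro on an aromatic carbon, the expected step is a 1.2-fold higher number from compound 3 to compound 4 (0.08 log units; within the scatter), resting on the earlier step of a 1.2-fold higher number from compound 1 to compound 2 (0.07 log units; within the scatter). Compound 4 is therefore estimated at 5700 nM in this assay, with the likely range expected to run from 3000 nM to 11000 nM.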

Compound 4, half-maximal inhibitory concentration: 6800 nM
Estimate against measurement, compound 4: 1.2-fold (0.08 log units) below, within the range that was stated.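

In this assay, going from the 3,4,5-trimethoxyphenyl to the 3,5-dimethoxyphenyl on the acetamido core gives a 1.4-fold higher number from compound 3 to compound 4 (0.16 log units; within the scatter), and this step agrees with the one seen on the fluoro core: the same change on two cores in this assay, a 1.2-fold higher number (0.07 log units; within the scatter) from compound 1 to compound 2 and a 1.4-fold higher number (0.16 log units; within the scatter) from compound 3 to compound 4, 1.2-fold (0.09 log units) apart, within the scatter of two such steps. The exchange of fluoro for acetamido, now read on the 3,5-dimethoxyphenyl core as a 1.4-fold lower number from compound 2 to compound 4 (0.14 log units; within the scatter), agrees in the same way with its earlier step: the same change on two cores in this assay, a 1.7-fold lower number (0.22 log units; within the scatter) from compound 1 to compound 3 and a 1.4-fold lower number (0.14 log units; within the scatter) from compound 2 to compound 4, 1.2-fold (0.09 log units) apart, within the scatter of two such steps. Among these compounds, each change thus reads alike on the two cores tried, but since every one of these steps lies within the scatter, this shows only that neither change moved the number beyond the scatter on these cores, not that either change has a real effect of a size that carries over, and two cores make no rule for any others.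

Going by these compounds, whether the same picture would hold with an amine, a carboxylic acid or a longer chain in the place of fluoro and acetamido stays open, as does the outcome of a hydroxyl or an ethoxy group in the place of the methoxy. On these data alone, all four compounds also share the rest of the core and were read in one assay, so how these steps behave on a different core or in other cells remains unknown.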